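Cyclopentylamino replacing morpholin-4-yl on the sulfonyl sulfur

A few compounds are considered here, and "the series" means these few. Any claim that something is new, unique, unknown or untested is made for them only; others in the source may bear on it.

In a physicochemical assay for solubility, in phosphate buffer, measured as kinetic solubility, at pH 7.4, tested at 250 uM (on this read-out higher numbers stand for higher solubility and lower numbers for lower solubility), compound 3 (`O=C(O)c1ccc(NCCCCCCCC(F)(F)F)c(S(=O)(=O)N2CCOCC2)c1`) gives 244000 nM. Compound 1 (`CNS(=O)(=O)c1cc(C(=O)O)ccc1NCCCCCCCC(F)(F)F`) gives 242000 nM, within the scatter of compound 3, while compound 2 (`O=C(O)c1ccc(NCCCCCCCC(F)(F)F)c(S(=O)(=O)N2CCCCC2)c1`) gives 13000 nM, well beyond the scatter under both.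

Compound 4 (`O=C(O)c1ccc(NCCCCCCCC(F)(F)F)c(S(=O)(=O)NC2CCCC2)c1`) has cyclopentylamino in place of morpholin-4-yl on a sulfonyl sulfur.

Among the measured compounds shown here, three measured steps bear on this change, all at the same place. Changing the group on the sulfonyl sulfur gave a 1.0-fold higher number from compound 1 to compound 3 (0.00 log units; within the scatter), but also a 19-fold lower number from compound 1 to compound 2 (1.27 log units; beyond the scatter) and a 19-fold higher number from compound 2 to compound 3 (1.27 log units; beyond the scatter), so the outcome depends strongly on the group. The entering group is an amino group, as methylamino is in compound 1, and its ring has no oxygen, as piperidin-1-yl has none in compound 2. For the measured compounds named here, no measured compound combines these two features, so the direction is uncertain, though a drop is the more likely outcome.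

The expected change is a 6.1-fold lower number from compound 3 to compound 4 (0.79 log units; beyond the scatter), a drop smaller than the largest measured step. For compound 4 the estimated value is 40000 nM, with an expected range of 10000 nM to 150000 nM.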

Compound 4, solubility: 223000 nM
Compound 4: middle estimate off by 5.6-fold (0.75 log units), on the low side; the whole stated range lies below it.
By their numbers in this assay, from the lowest: compound 2; then compounds 4, 1 and 3 (each within the scatter of the next).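

In this assay, a ring of carbon only on the sulfonyl sulfur does not by itself go with the low number of compound 2: the exchange for morpholin-4-yl gives a 1.1-fold lower number from compound 3 to compound 4 (0.04 log units; within the scatter), whereas the exchange for piperidin-1-yl gives a 17-fold higher number from compound 2 to compound 4 (1.23 log units; beyond the scatter). Cyclopentyl in place of methyl on a sulfonamide nitrogen also leaves the number in place (a 1.1-fold lower number from compound 1 to compound 4 (0.04 log units; within the scatter)). Among the compounds shown here, compound 2 is therefore the only compound of the four that stands apart, and it differs from compound 4 in carrying piperidin-1-yl rather than cyclopentylamino.

Nothing shown explains the gap between compound 2 and the other three. As far as these compounds go, it remains open whether pyrrolidin-1-yl or cyclohexylamino on the sulfonyl sulfur would fall with compound 2 or with compound 4.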